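The compounds below may be only part of what the source reports. "The series", "measured", "known", "first", "only" and "open" are said of these compounds alone.

Measured compounds in this series:

- compound 1, `CC(C)C(=O)OCn1oc(=O)c2ccccc21`; in a functional assay on L1210 cells (Mus musculus) for cytotoxicity (a lower number here means a stronger inhibitor, a higher number a weaker inhibitor), compound 1 gives 5.3 ug/mL; 20 ug/mL (2 entries)
- compound 2, `CC(C)(C)C(=O)OCn1oc(=O)c2ccccc21`; in this assay compound 2 gives 4.2 ug/mL; 16 ug/mL (2 entries)
- compound 3, `Cc1ccc(C(=O)OCn2oc(=O)c3ccccc32)cc1`; in this assay compound 3 gives 4.6 ug/mL

Compound 3 stands on a single figure in this assay; two further entries for it carry no single number. For the measured compounds named here, its one value sits in the same range as those of compound 1 and compound 2, whose repeated entries (the several entries of compound 1 in this assay, 5.3 ug/mL; 20 ug/mL (2 entries); (the several entries of compound 2 in this assay, 4.2 ug/mL; 16 ug/mL (2 entries))) scatter over a band wide enough that none of the three can be separated from the others. The shared core of compounds 1 to 3 differs only in the group on the carbonyl carbon of the ester.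

The step now followed leads from compound 3 to compound 4, `CNC(=O)OCn1oc(=O)c2ccccc21`, which has not yet been measured in this assay. The change is methylamino in place of 4-methylphenyl on a carbonyl carbon, the site being the carbonyl carbon whose other neighbour is the oxygen next to a carbonyl group. Going by the values given here, no comparable pair of measured compounds exists, so the size of this step is open; the three measured compounds, with very different groups on that carbonyl carbon, give no sign of a step beyond the scatter, so for compound 4 a small shift, if any, is expected in this assay, with the estimated step being a 1.7-fold higher number from compound 3 to compound 4 (0.24 log units; within the scatter). Compound 4 is expected to give about 8 ug/mL, with a likely range from 3 ug/mL to 25 ug/mL.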

Compound 4, concentration for 50% inhibition: 3.5 ug/mL
For compound 4 the middle estimate is 2.3-fold (0.36 log units) above the measured one, within the range that was stated.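

In this assay, for the compounds shown here, methylamino in place of 4-methylphenyl on a carbonyl carbon gives a 1.3-fold lower number from compound 3 to compound 4 (0.12 log units; within the scatter), the first step that can be read at this position, and it shows that this position tolerates the exchange of a six-membered aromatic ring of carbon only for a small group with no ring and one hydrogen-bond donor without a shift beyond the scatter. That step is also narrower than the spread between repeated entries of a compound with a different group at this site: the several entries of compound 1 in this assay, 5.3 ug/mL; 20 ug/mL (2 entries). The same comparison holds for a second compound, so this change cannot be distinguished from repeat variation: the several entries of compound 2 in this assay, 4.2 ug/mL; 16 ug/mL (2 entries).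

On these data alone, it remains open whether any group on this carbonyl carbon can move the number in this assay beyond the scatter, or whether the read-out is set by the shared core. A dimethylamino group, which has no hydrogen on the nitrogen, or a longer chain such as octylamino in the same place would test the limits of this tolerance.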